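Swapping halogenated benzyl groups on a cytotoxicity read-out

The source may hold more compounds than are shown below. What is called first, only, known or untested is meant among the compounds shown, and "the series" means these compounds.

Compound 1 `Fc1cccc(F)c1Cn1ccc2nc(-c3ccccc3)nc-2c1` carries a 2,6-difluorophenyl group on a saturated chain carbon bound to an aromatic nitrogen of the shared core. In an ADME assay on MDBK cells (Bos taurus) for cytotoxicity (on this read-out higher numbers stand for lower toxicity in this test and lower numbers for higher toxicity in this test), compound 1 gives > 100000 nM, which is a limit of this assay rather than a number. Compound 2 `Fc1ccccc1Cn1ccc2nc(-c3ccccc3)nc-2c1` is the same molecule with hydrogen in place of fluoro on an aromatic carbon; in this assay compound 2 gives > 100000 nM, again a limit. Compound 3 `Clc1ccc(Cn2ccc3nc(-c4ccccc4)nc-3c2)cc1` carries a 4-chlorophenyl group instead; in this assay compound 3 gives > 100000 nM, also a limit. The steps a step that the two limits leave unreadable from compound 1 to compound 2, a step that the two limits leave unreadable from compound 1 to compound 3 and a step that the two limits leave unreadable from compound 2 to compound 3 therefore cannot be sized, because of the limit of > 100000 nM in this assay, at which 3 of the 3 values shown sit.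

Compound 4 `Clc1ccc(Cn2ccc3nc(-c4ccccc4)nc-3c2)cc1Cl` is not yet measured. It differs from compound 1 as follows: 3,4-dichlorophenyl in place of 2,6-difluorophenyl on a saturated chain carbon bound to an aromatic nitrogen. The steps from compound 1 to compound 3 and from compound 2 to compound 3 bear most closely on this change, since both also bring a chlorophenyl group into the same place, and both left the read-out at the limit. Going by the values given here, no step visible here points toward higher or lower toxicity beyond the scatter, so the expected step of a number no higher from compound 1 to compound 4 (the limit leaves the size open) is essentially none. Compound 4 is therefore estimated to give 100000 nM in this assay, within a range of 40000 nM to 250000 nM, most likely as a limit once more.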

Compound 4, half-maximal cytotoxic concentration: 71000 nM
Compound 4: the middle estimate sits 1.4-fold (0.15 log units) above what was measured; the measured number falls inside the stated range.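

In this assay compound 4 gives 71000 nM, the only read-out among these compounds that is a number rather than a limit, so 3,4-dichlorophenyl on a saturated chain carbon bound to an aromatic nitrogen brings the read-out within the assay's measurable range. One added chloro on an aromatic carbon gives an at least 1.4-fold lower number from compound 3 to compound 4 (0.14 log units; that floor lies within the scatter), while the swaps of the fluorinated phenyl groups give an at least 1.4-fold lower number from compound 1 to compound 4 (0.14 log units; that floor lies within the scatter) and an at least 1.4-fold lower number from compound 2 to compound 4 (0.14 log units; that floor lies within the scatter). These are floors that do not by themselves show a real change in toxicity, and the true sizes stay open because the starting values are limits: the limit of > 100000 nM in this assay, at which 3 of the 4 values shown sit.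

On these data alone, it remains open how the read-out would respond to a different kind of substituent on this phenyl ring, such as an amine or a carboxylic acid, or to a longer chain in place of the saturated chain carbon. The phenyl group on the shared core is also the same in all four compounds, so these results say nothing about how changing it would affect the read-out.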